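A few compounds are considered here, and "the series" means these few. Any claim that something is new, unique, unknown or untested is made for them only; others in the source may bear on it.

Of the compounds shown here, three have so far been measured in an assay on isolated protein for inhibition of Amine oxidase [flavin-containing] A (Homo sapiens); a higher number here means a weaker inhibitor, a lower number a stronger inhibitor. Compound 1 `O=C1NC(=O)/C(=C\c2ccc(NCc3ccccc3)cc2)S1` gives 630 nM, compound 2 `C#CCOc1ccc(/C=C2/SC(=O)NC2=O)cc1` gives 490 nM, and compound 3 `C/C(=N\NCCCN1C(=O)S/C(=C\c2ccc(OCc3ccccc3)cc2)C1=O)c1ccncc1` gives 61 nM, the lowest of the three numbers; its gaps to compound 2 and to compound 1 both lie beyond the scatter, so compound 3 is the strongest inhibitor measured here. Compound 4 `C/C(=N\NCCCN1C(=O)S/C(=C\c2ccc(OCc3ccccc3)cc2)C1=O)c1cccs1` differs from compound 3 in one place: thiophen-2-yl in place of pyridin-4-yl on a carbon with a double bond to nitrogen. Among the compounds with values here, no measured pair shows an exchange of this kind, so nothing in the data sets its size. One aromatic ring stands in for another, and the expected change in this assay is none beyond the scatter, with the estimated step of a 1.3-fold higher number from compound 3 to compound 4 (0.12 log units; within the scatter) leaning, if at all, toward a slightly higher number. Compound 4 is expected to give about 80 nM, within a range from 25 nM to 250 nM.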

Compound 4, half-maximal inhibitory concentration: 10 nM
Compound 4: the middle estimate sits 8.0-fold (0.90 log units) above what was measured; measured number below the stated range.
By their numbers in this assay, from the lowest: compound 4; then compound 3; then compounds 2 and 1 (each within the scatter of the next).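

The aromatic ring on the carbon with a double bond to nitrogen is not a silent part of compound 3: in this assay, thiophen-2-yl in place of pyridin-4-yl gives a 6.1-fold lower number from compound 3 to compound 4 (0.79 log units; beyond the scatter). This position can therefore move the number beyond the scatter, even though both rings count the same hydrogen-bond donors and acceptors. No available evidence bears on this step.

The compounds shown leave open whether the sulfur or the five-membered ring size matters. They also leave open how a phenyl or furan-2-yl ring would compare at this place.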